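This account rests on a few compounds, and the source may have more. Where it says the series, first, only, none or still open, it means among the compounds named here.

In a functional assay on MDA-MB-231 cells (Homo sapiens) for antiproliferative activity, with a stated time of 4 days (on this read-out higher numbers stand for weaker inhibition and lower numbers for stronger inhibition), compound 1 `CCCCc1ccc2[nH]c(-c3ccc(OC)cc3)c(/C=N/NC(=O)c3cccc(OC)c3)c2c1` gives 55 nM, compound 2 `CCCCc1ccc2[nH]c(-c3ccc(OC)cc3)c(/C=N/NC(=O)c3ccccc3OC)c2c1` gives 21 nM and compound 3 `CCCCc1ccc2[nH]c(-c3ccc(OC)cc3)c(/C=N/NC(=O)c3cccnc3)c2c1` gives 35 nM. The first two are separated by a 2.6-fold lower number from compound 1 to compound 2 (0.42 log units; beyond the scatter). Compound 3 stands within the scatter of both, with a 1.6-fold lower number from compound 1 to compound 3 (0.20 log units; within the scatter) and a 1.7-fold higher number from compound 2 to compound 3 (0.22 log units; within the scatter). Compound 4 `CCCCc1ccc2[nH]c(-c3ccc(CC)cc3)c(/C=N/NC(=O)c3cccnc3)c2c1` changes one group of compound 3: ethyl in place of methoxy on an aromatic carbon. This puts ethyl in place of methoxy on an aromatic carbon, para to a large group. All measured steps lie on the carbonyl side, so none tests this change, and they offer only a rough sense of size. No step beyond the scatter is expected in this assay, and no direction can be argued. The estimate is a 1.1-fold higher number from compound 3 to compound 4 (0.06 log units; within the scatter). For compound 4 the expected value is 40 nM, in a range of 15 nM to 110 nM.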

Compound 4, half-maximal inhibitory concentration: 53 nM
Compound 4: middle estimate off by 1.3-fold (0.12 log units), on the low side; the range from low to high includes it.
By their numbers in this assay, from the lowest: compounds 2, 3, 4 and 1 (each within the scatter of the next, the first and the last beyond it).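

Unlike the earlier steps, all on the carbonyl side, this one tests the other end of the molecule: in this assay, a 1.5-fold higher number from compound 3 to compound 4 (0.18 log units; within the scatter) follows from replacing methoxy with ethyl. At this place, para to a large group, the change removes one hydrogen-bond acceptor without a step beyond the scatter. No measurement here explains this result. On these data alone, whether ethyl behaves the same way alongside the carbonyl groups of compound 1 or compound 2 remains open. So does the effect of an amine or a propyl chain here.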